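Methyl on the sulfur of compound 2: cytotoxicity note

This account rests on a few compounds, and the source may have more. Where it says the series, first, only, none or still open, it means among the compounds named here.

Of the compounds shown here, three of the shared core have been measured. Compound 1 `Cc1nc(S)n(Nc2ccc(Cl)cc2)c1-c1ccccc1` gives 134000 nM in a functional assay on MT4 cells (Homo sapiens) for cytotoxicity; a lower number here means that less compound is tolerated, a higher number that more compound is tolerated. Compound 2 `Cc1nc(S)n(Nc2cccc(Cl)c2)c1-c1ccccc1` gives 66700 nM in this assay, and compound 3 `Cc1nc(S)n(Nc2cccc(Cl)c2)c1-c1cccc(Br)c1` gives 44000 nM in this assay. Compound 2 stands second highest of the three numbers; its nearest neighbour is compound 3, with a 1.5-fold lower number from compound 2 to compound 3 (0.18 log units; within the scatter), and its furthest is compound 1, with a 2.0-fold lower number from compound 1 to compound 2 (0.30 log units; within the scatter), so all three values lie together within the scatter.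

Compound 4 `CSc1nc(C)c(-c2ccccc2)n1Nc1cccc(Cl)c1` differs from compound 2 in one place: methyl in place of hydrogen on a sulfur. Neither measured step touches that sulfur: a 2.0-fold lower number from compound 1 to compound 2 (0.30 log units; within the scatter) concerns 3-chlorophenyl in place of 4-chlorophenyl on a nitrogen on an aromatic ring, and a 1.5-fold lower number from compound 2 to compound 3 (0.18 log units; within the scatter) concerns bromo in place of hydrogen on an aromatic carbon, both within the scatter. Among the measured compounds shown here, no measured step on the sulfur exists, so the expectation rests only on the narrow spread of the three values and carries a wide range. For compound 4 a number near that of compound 2 is expected, estimated as 60000 nM with a range of 25000 nM to 150000 nM. This estimate means a 1.1-fold lower number from compound 2 to compound 4 (0.05 log units; within the scatter), a step expected to stay within the scatter.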

Compound 4, half-maximal cytotoxic concentration: 42100 nM
Compound 4: middle estimate off by 1.4-fold (0.15 log units), on the high side, and the stated range covers the measured number.
By their numbers in this assay, from the lowest: compounds 4, 3, 2 and 1 (each within the scatter of the next, the first and the last beyond it).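

Among the compounds shown here, the first change at this sulfur, sulfanyl to methylsulfanyl, gives a 1.6-fold lower number from compound 2 to compound 4 (0.20 log units; within the scatter) in this assay, so the number stays within the scatter. Replacing the hydrogen on this sulfur with methyl therefore does not separate compound 4 from compound 2 in this read-out, and the sulfur hydrogen is not needed to hold the number at the level of compound 2. Nothing shown gives a measured reason for this result.

Going by these compounds, whether the number also stays within the scatter with a longer chain on the sulfur, such as ethyl or benzyl, or with a chain ending in an amine or a carboxylic acid, remains open. Also open, on these data alone, is whether methylsulfanyl behaves the same way when combined with the bromo group of compound 3 or the 4-chlorophenyl group of compound 1.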